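Shifting one fluorine: from compound 3 to compound 4

A few compounds are considered here, and "the series" means these few. Any claim that something is new, unique, unknown or untested is made for them only; others in the source may bear on it.

In a functional assay on CHO cells with adenosine receptor A1 (Homo sapiens) as the target, read by cAMP accumulation and immunoassay, with a stated time of 6 min, tested at 10 uM (a lower number here means a stronger effect, a higher number a weaker effect of the compound at the concentration tested), three compounds have been measured:
compound 1 `Nc1scc(CN2CCN(c3ccc(F)cc3Cl)CC2)c1C(=O)c1ccc(Cl)cc1` gives -70%
compound 2 `Nc1scc(CN2CCN(c3cccc(F)c3)CC2)c1C(=O)c1ccc(Cl)cc1` gives -82%
compound 3 `Nc1scc(CN2CCN(c3c(F)cccc3F)CC2)c1C(=O)c1ccc(Cl)cc1` gives -80%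

Compound 3 stands second highest of the three, and both of its neighbours sit within the scatter: a number 2 percentage points higher from compound 2 to compound 3 (within the scatter) and a number 10 percentage points lower from compound 1 to compound 3 (within the scatter). For the measured compounds named here, the only step beyond the scatter is a number 12 percentage points lower from compound 1 to compound 2 (beyond the scatter), a modest one. Compound 4 `Nc1scc(CN2CCN(c3cc(F)ccc3F)CC2)c1C(=O)c1ccc(Cl)cc1` differs from compound 3 by 2,5-difluorophenyl in place of 2,6-difluorophenyl on an amine nitrogen in a ring. All three measured steps change the group on this same ring nitrogen, and two of them stayed within the scatter, so no step beyond the scatter is expected here: a number 2 percentage points higher from compound 3 to compound 4 (within the scatter). For compound 4 the estimated value is -78%, with an expected range from -92% to -62%.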

Compound 4, a percentage reported as activity, at one concentration (the size of the read-out at that concentration, not a potency): -80%
The estimate for compound 4 lay 2 percentage points above the measured number, and the stated range covers the measured number.
By their numbers in this assay, from the lowest: compounds 2, 3, 4 and 1 (each within the scatter of the next, the first and the last beyond it).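

In this assay, 2,5-difluorophenyl in place of 2,6-difluorophenyl on the ring nitrogen gives no change at the digits printed from compound 3 to compound 4 (within the scatter) and so shows that this fluorine shift leaves the read-out unmoved. Fluoro in place of hydrogen on an aromatic carbon gives a number 2 percentage points higher from compound 2 to compound 4 (within the scatter) and the exchange of 2-chloro-4-fluorophenyl gives a number 10 percentage points lower from compound 1 to compound 4 (within the scatter) so the second fluorine adds no step beyond the scatter. No available evidence bears on this result. On these data alone, whether a methoxy group or a nitrile on this phenyl ring would move the number remains open.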